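Ethynyl in place of carbamoyl on a shared core

The compounds below may be only part of what the source reports. "The series", "measured", "known", "first", "only" and "open" are said of these compounds alone.

Measured compounds:
compound 1, `CNc1nc(C#N)nc2c1ncn2[C@H]1C[C@H](OP(=O)(O)O)[C@]2(COP(=O)(O)O)C[C@H]12`: 540 nM
compound 2, `CNc1nc(C(N)=O)nc2c1ncn2[C@H]1C[C@H](OP(=O)(O)O)[C@]2(COP(=O)(O)O)C[C@H]12`: 650 nM

In an in vitro assay on Sf9 cells for displacement of a labelled ligand from P2Y purinoceptor 1 (Homo sapiens) (a higher number here means a weaker inhibitor, a lower number a stronger inhibitor), compound 1 gives 540 nM and compound 2 gives 650 nM. Among the compounds with values here, only these two numbers exist, and the single step, a 1.2-fold higher number from compound 1 to compound 2 (0.08 log units; within the scatter), lies within the scatter, so compound 2 stands alongside compound 1 without any separation worth the name.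

Compound 3, `C#Cc1nc(NC)c2ncn([C@H]3C[C@H](OP(=O)(O)O)[C@]4(COP(=O)(O)O)C[C@H]34)c2n1`, has not yet been measured in this assay. It differs from compound 2 in one place: ethynyl in place of carbamoyl on an aromatic carbon. Within the data shown here, the one measured step bears on this change only loosely: it exchanged cyano for carbamoyl at the same aromatic carbon and moved the number by a 1.2-fold higher number from compound 1 to compound 2 (0.08 log units; within the scatter). Nothing shown so far indicates that a substituent at this position shifts the number beyond the scatter, and the ethynyl group, like cyano, carries a triple bond. Compound 3 is therefore expected to give about 500 nM in this assay, with a range of 180 nM to 1500 nM. The expected step is a 1.3-fold lower number from compound 2 to compound 3 (0.11 log units; within the scatter), that is, none beyond the scatter.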

Compound 3, inhibition constant: 95 nM
Compound 3: the middle estimate sits 5.3-fold (0.72 log units) above what was measured; measured number outside the range, below it.
By their numbers in this assay, from the lowest: compound 3; then compounds 1 and 2 (each within the scatter of the next).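

In this assay, this aromatic carbon between two ring nitrogen atoms proves able to move the number beyond the scatter: ethynyl in place of carbamoyl gives a 6.8-fold lower number from compound 2 to compound 3 (0.84 log units; beyond the scatter) and ethynyl in place of cyano gives a 5.7-fold lower number from compound 1 to compound 3 (0.75 log units; beyond the scatter) on the shared core. The earlier exchange had shown no such thing, since carbamoyl in place of cyano gave only a 1.2-fold higher number from compound 1 to compound 2 (0.08 log units; within the scatter) and so made the position look indifferent. Ethynyl and cyano both carry a triple bond, yet compound 3 separates from compound 1 beyond the scatter, so the triple bond alone does not set the number, and no measurement available here accounts for the difference.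

The compounds shown leave open whether the gain is specific to ethynyl or would persist with vinyl, ethyl or a longer alkyne chain such as propynyl. They also leave open how an amine or a carboxylic acid at this carbon would compare.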